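Compound 3: 4-chlorobenzyl in place of 3-(trifluoromethyl)phenyl

The source may report more compounds than this note shows. Statements on the series, on what has been measured and on what is new or still open speak of the compounds shown alone.

Within the data shown here, in a functional assay on MDA-MB-231 cells (Homo sapiens) for inhibition, read by MTT assay, with a stated time of 48 h (on this read-out lower numbers stand for stronger inhibition of growth and higher numbers for weaker inhibition of growth), compound 1 `Fc1ccc(NC(=S)Nc2ccc3ncnc(Nc4cccc(Br)c4)c3c2)cc1Cl` gives 300 nM and compound 2 `FC(F)(F)c1cccc(NC(=S)Nc2ccc3ncnc(Nc4cccc(Br)c4)c3c2)c1` gives 1400 nM as the higher of the only two numbers so far, which stands for the weaker inhibition of growth. Compound 3 `S=C(NCc1ccc(Cl)cc1)Nc1ccc2ncnc(Nc3cccc(Br)c3)c2c1` carries 4-chlorobenzyl in place of 3-(trifluoromethyl)phenyl on an amide-type nitrogen and keeps the rest of compound 2 unchanged. Among the measured compounds shown here, only one measured step bears on this change: a 4.7-fold higher number from compound 1 to compound 2 (0.67 log units; beyond the scatter) is an exchange of one group for another at that same nitrogen, and it is modest but beyond the scatter. For the measured compounds named here, no measured compound carries a benzyl group, so the direction of the new step remains open, and a step of about that modest size could go either way. The expected change is small, with a 1.4-fold lower number from compound 2 to compound 3 (0.15 log units; within the scatter) as the estimate and no clear shift beyond the scatter anticipated. In this assay compound 3 is expected at 1000 nM with an estimated range from 300 nM to 3500 nM.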

Compound 3, concentration for 50% growth inhibition: 23000 nM
Compound 3: middle estimate off by 23-fold (1.36 log units), on the low side; measured number above the stated range.
By their numbers in this assay, from the lowest: compound 1; then compound 2; then compound 3.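

At the amide-type nitrogen whose other neighbour is the thiocarbonyl carbon, 4-chlorobenzyl in place of 3-(trifluoromethyl)phenyl gives a 16-fold higher number from compound 2 to compound 3 (1.22 log units; beyond the scatter) and is classed as large, as is 4-chlorobenzyl in place of 3-chloro-4-fluorophenyl with a 77-fold higher number from compound 1 to compound 3 (1.88 log units; beyond the scatter) on the same read-out. Among these compounds, the only earlier step at this nitrogen, a 4.7-fold higher number from compound 1 to compound 2 (0.67 log units; beyond the scatter) between the two substituted phenyl groups, was modest, so the position proves far less forgiving of a change to 4-chlorobenzyl than that step alone could show. No measurement shown here accounts for this result.

The compounds shown leave open whether the loss goes with the benzyl group as a whole or with its chlorine. They also leave open how an unsubstituted benzyl, a longer chain such as 2-phenylethyl, or a cyclohexyl group would behave at this nitrogen.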